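Swapping the aryl group on a fused six-ring core

The compounds below may be only part of what the source reports. "The series", "measured", "known", "first", "only" and "open" are said of these compounds alone.

Measured compounds:
- Compound 1, `Cc1nc2c3ccccc3ccc2c2nc3c(ccc4ccccc43)c(-c3cccnc3)c12`: 156 ug/mL
- Compound 2, `Cc1nc2c3ccccc3ccc2c2nc3c(ccc4ccccc43)c(-c3ccc(O)cc3)c12`: 99 ug/mL
- Compound 3, `Cc1ccc(-c2c3ccc4ccccc4c3nc3c2c(C)nc2c4ccccc4ccc32)cc1`: 192 ug/mL

These three compounds share one core and differ only in the aromatic group attached to it. In a functional assay, with a stated time of 90 s (a lower number here means a stronger inhibitor, a higher number a weaker inhibitor), compound 3 gives 192 ug/mL, the highest of the three numbers, yet its steps to the other two stay within the scatter: a 1.2-fold higher number from compound 1 to compound 3 (0.09 log units; within the scatter) and a 1.9-fold higher number from compound 2 to compound 3 (0.29 log units; within the scatter). Nothing here separates the three compounds with confidence.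

Compound 4, `Cc1nc2c3ccccc3ccc2c2nc3c(ccc4ccccc43)c(-c3cc(O)nc4ccccc34)c12`, has not been measured. It differs from compound 3 in one place: 2-hydroxyquinolin-4-yl in place of 4-methylphenyl on an aromatic carbon. The incoming group carries a hydroxy and a ring nitrogen, so two earlier steps bear on it. Replacing hydroxy by methyl gave a 1.9-fold higher number from compound 2 to compound 3 (0.29 log units; within the scatter), and replacing pyridin-3-yl by 4-methylphenyl gave a 1.2-fold higher number from compound 1 to compound 3 (0.09 log units; within the scatter). Both were small and within the scatter, and both point the same way. The step to compound 4 is therefore expected to be modest and towards a lower number, comparable to the step that separates compound 2 from compound 3, and may itself fall within the scatter: a 1.7-fold lower number from compound 3 to compound 4 (0.24 log units; within the scatter).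

Compound 4 is estimated to give 110 ug/mL in this assay, with a likely range from 55 ug/mL to 220 ug/mL.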

Compound 4, half-maximal inhibitory concentration: 148 ug/mL
For compound 4 the middle estimate is 1.3-fold (0.13 log units) below the measured one; the measured number falls inside the stated range.
By their numbers in this assay, from the lowest: compounds 2, 4, 1 and 3 (each within the scatter of the next).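

Compound 4 shows that this position, on the aromatic carbon opposite the ring nitrogen, can carry a group with more heavy atoms and a second aromatic ring without the number in this assay leaving the scatter. Exchanging 4-methylphenyl for 2-hydroxyquinolin-4-yl gives a small step (a 1.3-fold lower number from compound 3 to compound 4 (0.11 log units; within the scatter)), and the steps from the two other aryl groups are also small: from 4-hydroxyphenyl (a 1.5-fold higher number from compound 2 to compound 4 (0.17 log units; within the scatter)) and from pyridin-3-yl (a 1.1-fold lower number from compound 1 to compound 4 (0.02 log units; within the scatter)), so all four compounds remain within the scatter of their neighbours in the ranking and this change does not separate them. No supporting measurement is available to explain why these numbers stay so close.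

Within the data shown here, every group at this position so far is a six-membered aromatic ring or a two-ring system containing one, so it remains open whether an amine, a carboxylic acid or a longer chain in the same place would give a step beyond the scatter. Going by these compounds, the methyl group on the shared core is also the same throughout, so what happens to the number when it is replaced, for example by hydrogen or ethyl, remains unknown.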